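Swapping chloro for fluoro on the benzyl group

The source may hold more compounds than are shown below. What is called first, only, known or untested is meant among the compounds shown, and "the series" means these compounds.

Measured compounds in an ADME assay for permeability, using PAMPA; on this read-out higher numbers stand for higher permeability and lower numbers for lower permeability:
- compound 1, `CCCC[C@H](NC(=O)[C@H](CCCCN)NC(=O)[C@H](CCCNC(=N)N)NC(=O)c1ccc(/C=C2\SC(=O)N(C3CCCCC3)C2=O)cc1)C(N)=O`: 1.69 10^-6 cm/s
- compound 2, `CCCC[C@H](NC(=O)[C@H](CCCCN)NC(=O)[C@H](CCCNC(=N)N)NC(=O)c1ccc(/C=C2\SC(=O)N(c3ccc(C)cc3)C2=O)cc1)C(N)=O`: 0.66 10^-6 cm/s
- compound 3, `CCCC[C@H](NC(=O)[C@H](CCCCN)NC(=O)[C@H](CCCNC(=N)N)NC(=O)c1ccc(/C=C2\SC(=O)N(Cc3ccc(Cl)cc3)C2=O)cc1)C(N)=O`: 1.11 10^-6 cm/s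

All three compounds share one core and differ only in the group attached to an amide-type nitrogen in a ring. Compound 3, which carries a 4-chlorobenzyl there, stands second highest of the three numbers in this assay; the gap to compound 1, given by a 1.5-fold lower number from compound 1 to compound 3 (0.18 log units; within the scatter), and the gap to compound 2, given by a 1.7-fold higher number from compound 2 to compound 3 (0.23 log units; within the scatter), are both within the usual scatter, so the three values are best read as close together. Within the data shown here, only the step of a 2.6-fold lower number from compound 1 to compound 2 (0.41 log units; beyond the scatter) reaches beyond the scatter.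

Compound 4, `CCCC[C@H](NC(=O)[C@H](CCCCN)NC(=O)[C@H](CCCNC(=N)N)NC(=O)c1ccc(/C=C2\SC(=O)N(Cc3ccc(F)cc3)C2=O)cc1)C(N)=O`, differs from compound 3 by the change (fluoro in place of chloro on an aromatic carbon). Among the measured compounds shown here, none of the measured steps makes this same exchange; the closest steps, a 1.5-fold lower number from compound 1 to compound 3 (0.18 log units; within the scatter) and a 1.7-fold higher number from compound 2 to compound 3 (0.23 log units; within the scatter), replace the whole group on the ring nitrogen and still stay within the scatter. A single halogen swap at the far end of that group is therefore expected to give no step beyond the scatter, and the estimated step is a 1.2-fold lower number from compound 3 to compound 4 (0.07 log units; within the scatter). Compound 4 is expected to show about 0.95 10^-6 cm/s, within a range from 0.5 10^-6 cm/s to 1.8 10^-6 cm/s.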

Compound 4, apparent permeability: 0.43 10^-6 cm/s
The estimate for compound 4 lay 2.2-fold (0.34 log units) above the measured number; measured number below the stated range.
By their numbers in this assay, from the lowest: compounds 4, 2, 3 and 1 (each within the scatter of the next, the first and the last beyond it).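

In this assay, an exchange of one heavy atom for one heavy atom, fluoro in place of chloro on an aromatic carbon, gives a 2.6-fold lower number from compound 3 to compound 4 (0.41 log units; beyond the scatter). Among the earlier compounds, only a replacement of the whole group on the ring nitrogen gave a step beyond the scatter, so this position is now seen to respond to the halogen alone, and the two benzyl compounds cannot be treated as interchangeable. The choice of halogen also alters how the benzyl compounds compare with the others: compound 3 lay within the scatter of compound 1, but a 3.9-fold lower number from compound 1 to compound 4 (0.59 log units; beyond the scatter) goes beyond it, while a 1.5-fold lower number from compound 2 to compound 4 (0.19 log units; within the scatter) stays within it.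

Nothing given here bears on why the halogen swap moved the number. The compounds shown leave open where a bromo, a methyl or a plain hydrogen on the same aromatic carbon of the benzyl group would fall in this assay, and so whether chloro or fluoro is the exception in such a series.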